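The source may report more compounds than this note shows. Statements on the series, on what has been measured and on what is new or still open speak of the compounds shown alone.

Working notes on the series. In a functional assay (aorta) with Oryctolagus cuniculus as the target (a higher number here means weaker binding, a lower number tighter binding), compound 1 `CCc1ccc(OCCCN2CCC(C(c3ccc(F)cc3)c3ccc(F)cc3)CC2)c(OC)c1` gives 2.51 nM as its value, compound 2 `N#Cc1ccc(OCCCN2CCC(C(c3ccc(F)cc3)c3ccc(F)cc3)CC2)cc1` gives 5.01 nM as its value, and compound 3 `CC(C)(C)c1ccc(OCCCN2CCC(C(c3ccc(F)cc3)c3ccc(F)cc3)CC2)cc1` gives 1 nM as the lowest of the three numbers, with its gaps to both others beyond the scatter. The change to compound 4 `Fc1ccc(C(c2ccc(F)cc2)C2CCN(CCCCc3ccccc3)CC2)cc1` is benzyl in place of 4-(tert-butyl)phenoxy on a saturated chain carbon, three bonds along the chain from an amine nitrogen in a ring. The measured steps only swap the aryl group on the oxygen: a 2.0-fold higher number from compound 1 to compound 2 (0.30 log units; within the scatter) stays within the scatter, while a 2.5-fold lower number from compound 1 to compound 3 (0.40 log units; beyond the scatter) and a 5.0-fold lower number from compound 2 to compound 3 (0.70 log units; beyond the scatter) are modest. None of them removes the oxygen, so they bear on this change only indirectly. Compound 4 also loses the tert-butyl group, whose arrival in a 5.0-fold lower number from compound 2 to compound 3 (0.70 log units; beyond the scatter) came with a lower number. A modest move to a higher number is therefore expected in this assay for this change. The estimated step is a 2.5-fold higher number from compound 3 to compound 4 (0.40 log units; beyond the scatter) and is held loosely. For compound 4 the estimated value is 2.5 nM within an expected range of 0.8 nM to 8 nM on present evidence.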

Compound 4, dissociation constant: 2.51 nM
Compound 4: the middle estimate sits 1.0-fold (0.00 log units) below what was measured; measured number inside the range.
By their numbers in this assay, from the lowest: compound 3; then compounds 1, 4 and 2 (each within the scatter of the next).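

In this assay, among these compounds, this is the first change that takes out the chain oxygen, and with benzyl on the saturated chain carbon the result is no change at the digits printed from compound 1 to compound 4 (within the scatter) and a 2.0-fold lower number from compound 2 to compound 4 (0.30 log units; within the scatter), so a value of this order at this place does not depend on that oxygen. Only compound 3 stands apart, with a 2.5-fold higher number from compound 3 to compound 4 (0.40 log units; beyond the scatter), but this step removes the oxygen and the tert-butyl group together, so the two contributions cannot be separated. The data on hand offer no measurement that explains any of these steps.

From the compounds shown here alone, what the tert-butyl group contributes without the oxygen remains open, and a 4-(tert-butyl)benzyl group at this place would address that. Also open, going by these compounds, is whether an amine linking atom or a longer chain would be tolerated equally at this place.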